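The source may hold more compounds than are shown below. What is called first, only, known or untested is meant among the compounds shown, and "the series" means these compounds.

Measured so far:
compound 1, `CC(C)n1nc(-c2cc(C(C)(C)C)on2)c2c(N)ncnc21`: 7310 nM
compound 2, `Nc1ncnc2c1c(-c1cc(C3CC3)on1)nn2C1CCOCC1`: 1930 nM

Both compounds were tested in an assay on BaF3 cells for inhibition of proto-oncogene tyrosine-protein kinase receptor Ret variant V804M (Homo sapiens), read by MTT assay, with a stated time of 48 h; on this read-out lower numbers stand for stronger inhibition of growth and higher numbers for weaker inhibition of growth. Compound 1 gives 7310 nM, the higher of the two numbers. Compound 2 gives 1930 nM, and the gap between these two values lies beyond the usual scatter of repeated measurements, so compound 1 is the weaker of the pair. Compound 2 differs from compound 1 in more than one place, so the gap cannot be tied to a single change.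

Compound 3, `CCc1cc(-c2nn(C(C)C)c3ncnc(N)c23)no1`, has not been measured yet. It differs from compound 1 in one place: ethyl in place of tert-butyl on an aromatic carbon. The rest of the molecule stays as it is in compound 1. Going by the values given here, no pair of measured compounds differs only at this carbon of the five-membered ring, so the size of the step is open. Compound 2, which carries a cyclopropyl there among other changes, gives the lower number, which hints that a smaller group may help. Compound 3 is therefore expected to give a somewhat lower number than compound 1, a step of a 1.6-fold lower number from compound 1 to compound 3 (0.21 log units; within the scatter) that may still stay within the scatter. The estimate for compound 3 is 4500 nM, within 1500 nM to 12000 nM.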

Compound 3, concentration for 50% growth inhibition: 5770 nM
Compound 3: middle estimate off by 1.3-fold (0.11 log units), on the low side, within the range that was stated.
By their numbers in this assay, from the lowest: compound 2; then compounds 3 and 1 (each within the scatter of the next).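

In this assay, the tert-butyl on the aromatic carbon next to the ring oxygen can be cut back to ethyl, from four carbons to two, without a change that can be told from assay noise (a 1.3-fold lower number from compound 1 to compound 3 (0.10 log units; within the scatter)). Going by these compounds alone, this is the first clean reading at this carbon, since only this one group differs while the rest of the molecule stays the same, and it shows that, for these two groups, the read-out does not separate the larger group from the smaller one. No measurement shown here offers an explanation for this result.

A single step within the scatter cannot show whether this carbon is insensitive to its substituent in general, since both groups are plain carbon chains without a hydrogen-bond donor or acceptor. Going by these compounds, whether a group of another kind, such as an amine, a carboxylic acid or a phenyl ring, would shift the number at this carbon remains open, and so does the effect of a longer chain.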